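The compounds below may be only part of what the source reports. "The series", "measured", "known", "first", "only" and "open" are said of these compounds alone.

Compounds measured so far in an assay on membranes from HeLa cells for displacement of a labelled ligand from adenosine receptor A3 (Homo sapiens), read by scintillation counting, with a stated time of 180 min, tested at 1 uM; a higher number here means more inhibition at the concentration tested (going by the name of the read-out), a lower number less inhibition:

Compound 1, `CCCC(=O)C1=C(C)NC(=O)NC1c1ccco1`, gives 1%.
Compound 2, `CCN(CC)C(=O)C1=C(C)NC(=O)NC1c1ccco1`, gives 19%.
Compound 3, `CCSC(=O)C1=C(C)NC(=O)NC1c1ccco1`, gives 14%.

All three share one core and differ only in the group attached to the carbonyl carbon. Compound 3 stands second highest of the three: compound 2 sits above it, but the gap, a number 5 percentage points lower from compound 2 to compound 3 (within the scatter), lies within the scatter, so the two cannot be ordered. Compound 1 sits clearly below, as shown by a number 13 percentage points higher from compound 1 to compound 3 (beyond the scatter).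

Compound 4, `CC1=C(C(=O)OC2CCCC2)C(c2ccco2)NC(=O)N1`, has not yet been measured. It differs from compound 3 in one place: cyclopentyloxy in place of ethylsulfanyl on a carbonyl carbon. The change again swaps the group on the carbonyl carbon, so the two earlier swaps at that same position bear on it. One of them, a number 13 percentage points higher from compound 1 to compound 3 (beyond the scatter), was a modest rise beyond the scatter; the other, a number 5 percentage points lower from compound 2 to compound 3 (within the scatter), stayed within it. Such swaps have so far moved the read-out only modestly, and no measured compound carries a cyclopentyloxy group, so no clear direction can be read from the data.

The step from compound 3 to compound 4 is therefore expected to be small, a number 2 percentage points lower from compound 3 to compound 4 (within the scatter), with either sign possible. Compound 4 is estimated at 12%, within a range from 0% to 30%.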

Compound 4, a percentage reported as inhibition, at one concentration (the size of the read-out at that concentration, not a potency): 14%
The estimate for compound 4 lay 2 percentage points below the measured number; low and high end bracket the measured number.
By their numbers in this assay, from the lowest: compound 1; then compounds 3, 4 and 2 (each within the scatter of the next).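

In this assay, among the compounds shown here, the group on the carbonyl carbon carries a ring for the first time, as cyclopentyloxy with its five-membered ring of carbon only replaces the open ethylsulfanyl, and the read-out does not respond (no change at the digits printed from compound 3 to compound 4 (within the scatter)). For the compounds shown here, the same holds against the diethylamino group of compound 2 (a number 5 percentage points lower from compound 2 to compound 4 (within the scatter)), so compounds 2, 3 and 4, whose groups join the carbonyl carbon through nitrogen, sulfur and oxygen, cannot be told apart, while compound 1, with propyl joined through carbon, remains the one compound set apart, as a modest step shows (a number 13 percentage points higher from compound 1 to compound 4 (beyond the scatter)). No measurement available here explains why these different groups give such similar numbers.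

The compounds shown leave open whether a small ester such as ethoxy, a longer chain, a benzene ring or a primary amine on the carbonyl carbon would give a number beyond the scatter of this group of three. They also leave open what happens when the furan ring or another part of the shared core changes, since every compound here differs only at the carbonyl carbon.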